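Pyridinyl to Methoxymethylphenyl on the Shared Core

A few compounds are considered here, and "the series" means these few. Any claim that something is new, unique, unknown or untested is made for them only; others in the source may bear on it.

Compound 1 `CCC(CC)CNc1c(C(N)=O)cnc2ccc(C#N)cc12` gives 820 nM in an assay on HT-29 cells for inhibition of Serine-protein kinase ATM (Homo sapiens), read by fluorescence, with a stated time of 1 h (on this read-out higher numbers stand for weaker inhibition and lower numbers for stronger inhibition), compound 2 `CCC(CC)CNc1c(C(N)=O)cnc2ccc(-c3cccnc3)cc12` gives 73 nM, and compound 3 `CCC(CC)CNc1c(C(N)=O)cnc2ccc(-c3ccncc3)cc12` gives 418 nM. Compound 3 therefore holds the second highest of the three numbers, close to compound 1 and far from compound 2. Compound 4 `CCC(CC)CNc1c(C(N)=O)cnc2ccc(-c3ccc(COC)cc3)cc12` carries 4-(methoxymethyl)phenyl in place of pyridin-4-yl on an aromatic carbon. Among the measured compounds shown here, two measured steps bear on this change: a 2.0-fold lower number from compound 1 to compound 3 (0.29 log units; within the scatter), within the scatter, and a 5.7-fold higher number from compound 2 to compound 3 (0.76 log units; beyond the scatter), beyond it. As far as these compounds go, neither step involves a ring of carbon only, so the direction for compound 4 remains open, though a lower number seems somewhat more likely than a higher one in this assay. Compound 4 is estimated at 200 nM, within a range from 50 nM to 800 nM. The expected step is a 2.1-fold lower number from compound 3 to compound 4 (0.32 log units; beyond the scatter).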

Compound 4, half-maximal inhibitory concentration: 373 nM
The estimate for compound 4 lay 1.9-fold (0.27 log units) below the measured number; the range from low to high includes it.
By their numbers in this assay, from the lowest: compound 2; then compounds 4, 3 and 1 (each within the scatter of the next, the first and the last beyond it).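

In this assay 4-(methoxymethyl)phenyl, the only ring of carbon only shown at this position, stays within the scatter of pyridin-4-yl (a 1.1-fold lower number from compound 3 to compound 4 (0.05 log units; within the scatter)). It remains apart from pyridin-3-yl (a 5.1-fold higher number from compound 2 to compound 4 (0.71 log units; beyond the scatter)) and from cyano (a 2.2-fold lower number from compound 1 to compound 4 (0.34 log units; beyond the scatter)), so a ring nitrogen is not needed to reach this level, and compound 2 alone holds the lowest number. No available evidence accounts for these differences. Still open, as far as these compounds go, is whether plain phenyl, without the methoxymethyl chain, would match compound 4, and how an amine or a carboxylic acid on that ring would read.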